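Compound 3 and a Longer Group on Its Saturated Ring Carbon

The source may report more compounds than this note shows. Statements on the series, on what has been measured and on what is new or still open speak of the compounds shown alone.

In an ADME assay on Vero cells (Chlorocebus sabaeus) for cytotoxicity, read by sulforhodamine B assay, with a stated time of 3 days (a lower number here means that less compound is tolerated, a higher number that more compound is tolerated), compound 1 `CC1=C(C(=O)Nc2ccc(Cl)cc2)C(c2ccncc2)C(C(=O)Nc2ccc(Cl)cc2)=C(C)N1` gives 78 ug/mL and compound 2 `CC1=C(C(=O)Nc2ccc(Cl)cc2)C(c2cccc(Cl)c2)C(C(=O)Nc2ccc(Cl)cc2)=C(C)N1` gives 12 ug/mL on a core different from that of compound 3 `COc1ccc(NC(=O)C2=C(C)NC(=O)NC2c2ccccc2)cc1` which gives 225 ug/mL as the highest of the three numbers. The gap from compound 3 to each of the other two lies beyond the scatter, and compound 1 is the nearer of them.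

Compound 4 `COc1ccc(NC(=O)C2=C(C)NC(=O)NC2C/C=C/c2ccccc2)cc1` has not yet been measured. It carries 3-phenylprop-2-en-1-yl in place of phenyl on a saturated ring carbon, and the counted difference from compound 3 is 3-phenylprop-2-en-1-yl in place of phenyl on a saturated ring carbon at the same place on the shared core.

Within the data shown here, only one measured step bears on this change, and only loosely. It is a 6.5-fold lower number from compound 1 to compound 2 (0.81 log units; beyond the scatter) with 3-chlorophenyl in place of pyridin-4-yl on a saturated ring carbon. That step shows that a swap on such a carbon can move the number by a modest amount, although it belongs to another core and another pair of groups. Among the measured compounds shown here, no measured step extends a group as compound 4 does.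

A modest move toward less tolerated compound is therefore expected, an estimated 2.3-fold lower number from compound 3 to compound 4 (0.35 log units; beyond the scatter) in this assay for this change. Compound 4 is estimated at 100 ug/mL with an expected range from 35 ug/mL to 250 ug/mL for its number.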

Compound 4, half-maximal cytotoxic concentration: 15 ug/mL
For compound 4 the middle estimate is 6.7-fold (0.82 log units) above the measured one; measured number below the stated range.
By their numbers in this assay, from the lowest: compounds 2 and 4 (each within the scatter of the next); then compound 1; then compound 3.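

In this assay the change on the saturated ring carbon next to the ring nitrogen of the shared core gives a 15-fold lower number from compound 3 to compound 4 (1.18 log units; beyond the scatter) and so counts as a large step. It shows that this position responds strongly to 3-phenylprop-2-en-1-yl in place of phenyl, even though the six-membered aromatic ring of carbon only is kept and no hydrogen-bond donor, hydrogen-bond acceptor or net charge enters or leaves; the earlier step, a 6.5-fold lower number from compound 1 to compound 2 (0.81 log units; beyond the scatter) on another core, exchanged one ring for another and did not show what happens when a group is extended. Nothing measured here explains the size of this drop.

As far as these compounds go, it remains open whether the lower number goes with the longer link or with the double bond outside the aromatic ring, a question that a saturated 3-phenylpropyl chain and a shorter benzyl group at this carbon would help to separate. Also open, from the compounds shown here alone, are whether the same extension would act alike on the core of compound 1 and what an amine or a carboxylic acid at the end of the chain would do.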